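Amide Aryl Variation on a Shared Core

A few compounds are considered here, and "the series" means these few. Any claim that something is new, unique, unknown or untested is made for them only; others in the source may bear on it.

Compound 1 `COc1cc2ncnc(Nc3ccc(NC(=O)c4ccccc4OC)cc3)c2cc1OC`: in a functional assay on MCF7 cells (Homo sapiens) for inhibition, read by MTT assay (on this read-out lower numbers stand for stronger inhibition and higher numbers for weaker inhibition), compound 1 gives only a limit, > 100000 nM.
Compound 2 `COc1cc2ncnc(Nc3ccc(NC(=O)c4ccccc4F)cc3)c2cc1OC`: compound 2 gives 11000 nM.
Compound 3 `COc1cc2ncnc(Nc3ccc(NC(=O)c4ccc(F)cc4)cc3)c2cc1OC`: compound 3 gives 27000 nM.

Compound 2 has the lowest of the two numbers shown; compound 3 is its nearest neighbour, with a 2.5-fold higher number from compound 2 to compound 3 (0.39 log units; beyond the scatter). Compound 1 sits at the limit of this assay (the limit of > 100000 nM in this assay, at which 1 of the 3 values shown sits). From compound 1, fluoro in place of methoxy on an aromatic carbon gives an at least 9.0-fold lower number from compound 1 to compound 2 (0.95 log units; beyond the scatter), and 4-fluorophenyl in place of 2-methoxyphenyl on a carbonyl carbon gives an at least 3.7-fold lower number from compound 1 to compound 3 (0.56 log units; beyond the scatter).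

Compound 4 `COc1cc2ncnc(Nc3ccc(NC(=O)c4ccc(Cl)c(Cl)c4)cc3)c2cc1OC` is reached from compound 2 by 3,4-dichlorophenyl in place of 2-fluorophenyl on a carbonyl carbon. Among the measured compounds shown here, the measured step that bears on it is the one from compound 2 to compound 3, 4-fluorophenyl in place of 2-fluorophenyl on a carbonyl carbon, which gave a 2.5-fold higher number from compound 2 to compound 3 (0.39 log units; beyond the scatter). For the measured compounds named here, the swap of fluorine for two chlorines has no measured counterpart here. A modest step toward higher numbers in this assay is therefore expected for compound 4, a 1.8-fold higher number from compound 2 to compound 4 (0.26 log units; within the scatter), with wide uncertainty. Compound 4 is estimated at 20000 nM, expected to lie between 6000 nM and 70000 nM.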

Compound 4, half-maximal inhibitory concentration: 25000 nM
Beside the measured number, compound 4's estimate is 1.3-fold (0.10 log units) below it; low and high end bracket the measured number.
By their numbers in this assay, from the lowest: compound 2; then compounds 4 and 3 (each within the scatter of the next). At a limit, above all of these: compound 1.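

In this assay, 3,4-dichlorophenyl in place of 2-fluorophenyl on the carbonyl carbon gives a 2.3-fold higher number from compound 2 to compound 4 (0.36 log units; beyond the scatter), so compound 2 now stands apart from a second aryl amide and not only from compound 3. Set against the 4-fluorophenyl amide, the same group gives a 1.1-fold lower number from compound 3 to compound 4 (0.03 log units; within the scatter), so compound 3 and compound 4 cannot be told apart here, even though the aryl groups differ in both halogen and number of halogens. Against the 2-methoxyphenyl amide, 3,4-dichlorophenyl gives an at least 4.0-fold lower number from compound 1 to compound 4 (0.60 log units; beyond the scatter), and this step is only a bound, as the value for compound 1 is a limit: the limit of > 100000 nM in this assay, at which 1 of the 4 values shown sits.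

The aryl groups shown carry only fluorine, chlorine or methoxy, so it stays open how this position would respond to an amine, a carboxylic acid or a nitrile on the ring. It is also open whether the lower number of compound 2 belongs to fluorine in particular, as 2-chlorophenyl and unsubstituted phenyl are not among the compounds shown, and compound 1, with its 2-methoxyphenyl, does not share that lower number.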